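Swapping the thiophene for a furan in the shared core

A few compounds are considered here, and "the series" means these few. Any claim that something is new, unique, unknown or untested is made for them only; others in the source may bear on it.

Two pyridine-centred compounds have been measured in a functional assay on DU-145 cells (Homo sapiens) for cytotoxicity, read by CCK-8 assay; a higher number here means a weaker inhibitor, a lower number a stronger inhibitor. Compound 1 `Oc1ccc(-c2cc(-c3cccs3)cc(-c3cccc(O)c3)n2)cc1` gives 1890 nM in this assay. Compound 2 `Oc1ccc(-c2cc(-c3cccs3)cc(-c3ccc(O)cc3)n2)cc1`, which carries a 4-hydroxyphenyl in place of 3-hydroxyphenyl on an aromatic carbon, gives 2190 nM in this assay; the move a 1.2-fold higher number from compound 1 to compound 2 (0.06 log units; within the scatter) is within the scatter, so the two numbers are indistinguishable, even though compound 2 holds the higher of the two. Compound 3 `Oc1ccc(-c2cc(-c3ccoc3)cc(-c3ccc(O)cc3)n2)cc1` differs from compound 2 by furan-3-yl in place of thiophen-2-yl on an aromatic carbon. Among the measured compounds shown here, no measured step touches this position: the only step on record concerns the hydroxyphenyl arm, and it was flat. With no guide beyond that, the step from compound 2 to compound 3 is expected to be near zero in this assay, and the estimated step is a 1.1-fold higher number from compound 2 to compound 3 (0.06 log units; within the scatter), with wide uncertainty. Compound 3 is therefore estimated at 2500 nM in this assay, between 900 nM and 7000 nM.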

Compound 3, half-maximal inhibitory concentration: 3440 nM
Compound 3: middle estimate off by 1.4-fold (0.14 log units), on the low side; the range from low to high includes it.
By their numbers in this assay, from the lowest: compounds 1, 2 and 3 (each within the scatter of the next).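

At the position opposite the ring nitrogen, furan-3-yl in place of thiophen-2-yl yields a 1.6-fold higher number from compound 2 to compound 3 (0.20 log units; within the scatter) in this assay, so this position now has a reading of its own, and the exchange does not separate compound 3 from compound 2. The two groups match in heavy-atom count and in donor and acceptor counts, but the change swaps sulfur for oxygen and moves the point of attachment together, so the step cannot be assigned to either. No measurement bears on why the step has this size.

The compounds shown leave open whether furan-2-yl or thiophen-3-yl would tell those two changes apart. They also leave open how this position would respond to a group of another kind, such as an amine or a carboxylic acid.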